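From pyrrolidin-1-yl to methoxy on a carbonyl carbon

This account rests on a few compounds, and the source may have more. Where it says the series, first, only, none or still open, it means among the compounds named here.

Compound 1 (`COc1ccc(C(=O)/C=C/c2ccc(C(=O)N3CCCC3)cc2)c(O)c1`) gives > 100000 nM in an ADME assay on SH-SY5Y cells (Homo sapiens) for cytotoxicity, read by MTT assay, with a stated time of 48 h (a higher number here means a weaker inhibitor, a lower number a stronger inhibitor), and this is a limit of the assay, not a number. Compound 2 (`CCOCCCOc1ccc(/C=C/C(=O)c2ccc(OC)cc2O)cc1OC`) gives > 100000 nM in this assay, which is again only a limit. The series therefore stands on (the limit of > 100000 nM in this assay, at which 2 of the 2 values shown sit), and compound 1 cannot be placed more finely than that.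

Compound 3 (`COC(=O)c1ccc(/C=C/C(=O)c2ccc(OC)cc2O)cc1`) keeps the core of compound 1 and differs by methoxy in place of pyrrolidin-1-yl on a carbonyl carbon. In short, (pyrrolidin-1-yl)carbonyl becomes methoxycarbonyl. Going by the values given here, no measured pair shows what this exchange does. The step of a number no higher from compound 1 to compound 3 (the limit leaves the size open) is expected to stay within the usual scatter, with any movement more likely toward a lower number than a higher one. The expectation rests on compound 1, whose > 100000 nM is only a limit. A result for compound 3 that is again only a limit is considered more likely than not. The estimated value in this assay for compound 3 is 100000 nM, with an expected range of 35000 nM to 200000 nM.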

Compound 3, half-maximal inhibitory concentration: > 100000 nM
Compound 3 gave a limit, no number; the forecaster's own chance of this, stated with the estimate: 70%; the middle value sits exactly at the limit.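

No step can be read from compound 1 to compound 3 in this assay, since both results are limits and not numbers: the limit of > 100000 nM in this assay, at which 3 of the 3 values shown sit.

The compounds shown leave open where any of them would fall as an actual number in this assay, and so what methoxy in place of pyrrolidin-1-yl on a carbonyl carbon does there.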